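Hydroxy on the fused ring system of compound 3

This account rests on a few compounds, and the source may have more. Where it says the series, first, only, none or still open, it means among the compounds named here.

Measured in a functional assay on KB cells (Homo sapiens) for inhibition, read by sulforhodamine B assay; a higher number here means a weaker inhibitor of growth, a lower number a stronger inhibitor of growth:
- compound 1 `Oc1ccc(-c2ccc(-c3ccc(-c4nc5ccccc5[nH]4)cc3)cc2)cc1`: 41000 nM
- compound 2 `COc1ccc(-c2ccc(-c3ccc(-c4nc5ccccc5[nH]4)cc3)cc2)cc1`: 47200 nM
- compound 3 `Clc1cccc(-c2ccc(-c3ccc(-c4nc5ccccc5[nH]4)cc3)cc2)c1`: 32300 nM

Compound 3 stands level with the other two in this assay, as the steps to it stay within the scatter: a 1.3-fold lower number from compound 1 to compound 3 (0.10 log units; within the scatter) and a 1.5-fold lower number from compound 2 to compound 3 (0.16 log units; within the scatter). Compound 4 `Oc1cccc2[nH]c(-c3ccc(-c4ccc(-c5cccc(Cl)c5)cc4)cc3)nc12` carries hydroxy in place of hydrogen on an aromatic carbon of compound 3: hydroxy in place of hydrogen on an aromatic carbon.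

Within the data shown here, no measured step touches that ring, so the evidence is indirect. Among the measured compounds shown here, the only change made at a hydroxy group is methyl in place of hydrogen on an oxygen, at another ring: a 1.2-fold higher number from compound 1 to compound 2 (0.06 log units; within the scatter). The swaps of 4-hydroxyphenyl and 4-methoxyphenyl for 3-chlorophenyl were equally small. These steps give no reason to expect a shift in either direction, but they leave the new position untested, so the range is kept wide. The expected step is a 1.1-fold lower number from compound 3 to compound 4 (0.03 log units; within the scatter), with nothing expected beyond the scatter. For compound 4 the estimated value is 30000 nM, with an expected range of 10000 nM to 70000 nM.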

Compound 4, concentration for 50% growth inhibition: 2280 nM
Beside the measured number, compound 4's estimate is 13-fold (1.12 log units) above it, and the stated range ends above it.
By their numbers in this assay, from the lowest: compound 4; then compounds 3, 1 and 2 (each within the scatter of the next).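

In this assay, among these compounds, hydroxy in place of hydrogen on an aromatic carbon gives a 14-fold lower number from compound 3 to compound 4 (1.15 log units; beyond the scatter) and is the only step that lies beyond the scatter. The earlier steps shown here, methyl on the oxygen of compound 1 and the swaps to 3-chlorophenyl, all stayed within it, so this carbon of the fused system, ortho to a fused ring, is a place where one added hydroxy moves the number far more than any of those changes did. The data at hand offer no explanation for the size of this step.

As far as these compounds go, whether the effect is specific to hydroxy stays open, as methoxy, an amine or a carboxylic acid on the same carbon would test that. Also open, from the compounds shown here alone, is whether the step holds with 4-hydroxyphenyl or 4-methoxyphenyl in place of 3-chlorophenyl.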